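The source may report more compounds than this note shows. Statements on the series, on what has been measured and on what is new or still open speak of the compounds shown alone.

Three compounds share one core and differ only in the group attached to a carbonyl carbon whose other neighbour is an amide-type nitrogen. In a functional assay on MCF7 cells (Homo sapiens), read by MTT assay, with a stated time of 72 h (a lower number here means a stronger inhibitor, a higher number a weaker inhibitor), compound 1 `COc1cc(NC(C)CCCNC(=O)NCc2ccncc2)c2ncccc2c1` gives 30000 nM. Compound 2 `CCN(CC)C(=O)NCCCC(C)Nc1cc(OC)cc2cccnc12` reaches only a limit of the assay, > 63000 nM. Compound 3 `COc1cc(NC(C)CCCNC(=O)n2nnc3ccccc32)c2ncccc2c1` also shows only a limit of the assay, > 100000 nM. Compound 3 therefore stands as a weaker inhibitor than compound 1, since that exchange brought an at least 3.3-fold higher number from compound 1 to compound 3 (0.52 log units; beyond the scatter); the other exchange brought an at least 2.1-fold higher number from compound 1 to compound 2 (0.32 log units; beyond the scatter), while the step that the two limits leave unreadable from compound 2 to compound 3.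

Compound 4 `COc1cc(NC(C)CCCNC(=O)NCC2CCCCC2)c2ncccc2c1` differs from compound 3 in that (a group of 8 heavy atoms (7 carbon, 1 nitrogen; one six-membered non-aromatic ring of carbon only) in place of a group of 9 heavy atoms (6 carbon, 3 nitrogen; one five-membered aromatic ring with 3 hetero atoms, one six-membered aromatic ring of carbon only), on a carbonyl carbon). This change largely reverses the kind of exchange that gave an at least 3.3-fold higher number from compound 1 to compound 3 (0.52 log units; beyond the scatter), returning to a methylamino-type group bearing a ring, as in compound 1 with its 30000 nM. The number for compound 4 is therefore expected to fall, an estimated step of an at least 2.5-fold lower number from compound 3 to compound 4 (0.39 log units; beyond the scatter). For compound 4 the estimate in this assay is 40000 nM, with a range from 15000 nM to 100000 nM.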

Compound 4, half-maximal inhibitory concentration: 61000 nM
For compound 4 the middle estimate is 1.5-fold (0.18 log units) below the measured one, and the stated range covers the measured number.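

In this assay, going by these compounds alone, compound 4 gives the first direct ring-for-ring comparison at this position, with cyclohexyl in place of pyridin-4-yl on a saturated chain carbon bound to an amide-type nitrogen: a 2.0-fold higher number from compound 1 to compound 4 (0.31 log units; beyond the scatter). The aromatic ring with its hetero atom therefore goes with the lower number, although the step is only modest. Compounds 2 and 3 carry only limits of the assay, so the comparisons with them are floors that fix no order: an at least 1.6-fold lower number from compound 3 to compound 4 (0.21 log units; that floor lies within the scatter), and an at least 1.0-fold lower number from compound 2 to compound 4 (0.01 log units; that floor lies within the scatter).

The compounds shown leave open whether this step follows the ring nitrogen or the aromatic ring itself, which a phenyl group at the same place would help to separate. Also open, from the compounds shown here alone, is how a carboxylic acid on that ring would read.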